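A few compounds are considered here, and "the series" means these few. Any claim that something is new, unique, unknown or untested is made for them only; others in the source may bear on it.

Compound 1, `CCOc1ccc(F)cc1C(C)NC(=O)NS(=O)(=O)c1ccc(C)cc1`, in a functional assay on thoracic aorta (Rattus norvegicus, strain Wistar), with a stated time of 15 min; a higher number here means that more compound is needed for the effect, a lower number that less compound is needed: > 300000 nM
Compound 2, `CC(C)Oc1ccc(Br)cc1C(C)NC(=O)N(C)S(=O)(=O)c1ccccc1`: 32100 nM
Compound 3, `CCOc1ccc(F)cc1C(C)NC(=O)N(C)S(=O)(=O)c1ccc(C)cc1`: 7800 nM

The value of compound 1 is a limit of the assay and not a number; it sits at the limit of > 300000 nM in this assay, at which 1 of the 3 values shown sits, so only a floor is known for compound 1 in this assay. Going by the values given here, compound 3 gives 7800 nM in this assay, and the single-place step an at least 38-fold lower number from compound 1 to compound 3 (1.58 log units; beyond the scatter) is the only measured step in the set; it concerns methyl in place of hydrogen on an amide-type nitrogen. Compound 2 gives 32100 nM in this assay, but it differs from compound 3 in more than one place, so the two values stand on their own.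

Compound 4, `CCOc1ccc(Cl)cc1C(C)NC(=O)NS(=O)(=O)c1ccc(C)cc1`, differs from compound 1 by chloro in place of fluoro on an aromatic carbon. Among the compounds with values here, no measured step changes a halogen alone, and the step from compound 1 to compound 3 concerns another position, so it does not bear on this change. With nothing comparable measured, no shift beyond the scatter is expected. Compound 4 is therefore expected to give about 300000 nM in this assay, within 100000 nM to 1000000 nM. This corresponds to an expected step of a number no higher from compound 1 to compound 4 (the limit leaves the size open).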

Compound 4, half-maximal effective concentration: > 300000 nM
Compound 4: no number, only a limit; the forecaster's own chance of this, stated with the estimate: 75%; the middle value lies on the limit itself.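

Compound 4, like compound 1, gives only a limit of the assay and not a number, so no step between the two can be read: the limit of > 300000 nM in this assay, at which 2 of the 4 values shown sit.

The compounds shown leave open whether chloro in place of fluoro on the shared core shifts the number in this assay at all.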